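Shortening the alkyl chain at the carbonyl of compound 1

A few compounds are considered here, and "the series" means these few. Any claim that something is new, unique, unknown or untested is made for them only; others in the source may bear on it.

Compound 1 `Cc1cc(C(=O)O)ccc1OCCCCOc1ccc(C(=O)CC(C)C)c(O)c1C` stands lowest of the two compounds measured in an assay on HEK293 cells for positive allosteric modulation of metabotropic glutamate receptor 2 (Rattus norvegicus), read by thallium flux, with a stated time of 2.5 min (on this read-out lower numbers stand for smaller maximal responses and higher numbers for larger maximal responses), where compound 1 gives 83.9%. Among the compounds with values here, compound 2 `Cc1c(OCCCCOc2ccc(C(=O)O)cc2Cl)ccc(C(=O)CC(C)C)c1O` gives 99.5% in this assay; the step of a number 15.6 percentage points higher from compound 1 to compound 2 (beyond the scatter) exchanges chloro for methyl on an aromatic carbon and is the only measured step so far. Compound 3 `CCC(=O)c1ccc(OCCCCOc2ccc(C(=O)O)cc2C)c(C)c1O` differs from compound 1 on a saturated chain carbon bound to a carbonyl carbon: methyl in place of isopropyl on a saturated chain carbon bound to a carbonyl carbon. Within the data shown here, no measured step touches this part of the shared core; the one step known concerns an aromatic carbon and does not bear on the change from compound 1 to compound 3. The expectation for compound 3 in this assay therefore rests on compound 1 alone and amounts to no movement beyond the scatter, in either direction. For compound 3 the step of a number 1.9 percentage points lower from compound 1 to compound 3 (within the scatter) is the estimate, with wide limits given the lack of any relevant precedent. Compound 3 is expected to give 82% in this assay, with a range from 62% to 102%.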

Compound 3, largest response reached (reported as percent of maximum), in percent of the reference or control that the assay uses: 86.6%
The estimate for compound 3 lay 4.6 percentage points below the measured number; the range from low to high includes it.
By their numbers in this assay, from the lowest: compounds 1 and 3 (each within the scatter of the next); then compound 2.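

In this assay, the change from isobutylcarbonyl to propanoyl, with methyl in place of isopropyl on a saturated chain carbon bound to a carbonyl carbon, gives a number 2.7 percentage points higher from compound 1 to compound 3 (within the scatter), so the full isobutyl group is not needed to hold the maximal response at the level of compound 1. Within the data shown here, this is the first reading at this part of the shared core, and it separates the chain at the carbonyl from the aromatic carbon, where chloro in place of methyl gave a number 15.6 percentage points higher from compound 1 to compound 2 (beyond the scatter) in the same assay. No available data explain why the shortened chain leaves the response within the scatter.

Still open, from the compounds shown here alone, is how far this position stretches in either direction: whether a longer chain such as hexyl, a cyclopropyl or phenyl ring, or a hydroxyl or amine on the chain would leave the maximal response where compound 1 and compound 3 stand. Also open is whether the chloro exchange seen in compound 2 would carry over to the ethyl ketone of compound 3, since no compound shown holds both changes together.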